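A few compounds are considered here, and "the series" means these few. Any claim that something is new, unique, unknown or untested is made for them only; others in the source may bear on it.

Of the compounds shown here, three have been measured in an assay for antagonist activity at proteinase-activated receptor 4 (Homo sapiens), with stated times of 5 min, 50 s and 15 min, in the presence of a further agent that is not named here; on this read-out lower numbers stand for stronger inhibition and higher numbers for weaker inhibition. Compound 1, with structure `CCOc1nn2cc(-c3cc4ccccc4o3)nc2s1`, gives 2100 nM in this assay. This is the highest of the three numbers. Compound 2, with structure `COc1nn2cc(-c3cc4ccc(OCc5ccccc5)cc4o3)nc2s1`, gives 1800 nM in this assay, and the two values lie within the usual scatter of each other. Compound 3, with structure `COc1cc(OC)c2cc(-c3cn4nc(OC)sc4n3)oc2c1`, gives 74 nM in this assay, a much lower number that stands well beyond the scatter from compound 1.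

The step considered here leads from compound 1 to a compound not yet measured, compound 4, with structure `Cc1nn2cc(-c3cc4ccccc4o3)nc2s1`. The change is methyl in place of ethoxy on an aromatic carbon. Within the data shown here, no pair of measured compounds shows this change, so no measured step guides the expectation. Compounds 2 and 3 each carry a methoxy at this place, but they also differ elsewhere, so their values show only that this position tolerates a short group.

For compound 4 a step of a 1.4-fold higher number from compound 1 to compound 4 (0.15 log units; within the scatter) is expected, toward a weaker or similar value. The estimate for compound 4 in this assay is 3000 nM, within a range of 1000 nM to 9000 nM.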

Compound 4, half-maximal inhibitory concentration: > 30000 nM
Compound 4: a limit, no number; the forecaster's own chance of this, stated with the estimate: 15%; middle value at least 10-fold (1.00 log units) away from the limit.
By their numbers in this assay, from the lowest: compound 3; then compounds 2 and 1 (each within the scatter of the next). At a limit, above all of these: compound 4.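

Among these compounds, this single change shows that the position is far more sensitive than the earlier compounds could reveal: methyl in place of ethoxy on this aromatic carbon, with the rest of the molecule unchanged, gives an at least 14-fold higher number from compound 1 to compound 4 (1.15 log units; beyond the scatter). In this assay compound 4 gives > 30000 nM, which is a limit of the assay and not a number. Among the compounds shown, only one value sits at such a limit: the limit of > 30000 nM in this assay, at which 1 of the 4 values shown sits.

The compounds shown cannot tell whether the loss of the ether oxygen, the shorter group or both together account for this large step, and the full size of the step also stays unknown. From the compounds shown here alone, how an amine or a longer chain such as butoxy would behave at this place on the same core remains open.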